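A few compounds are considered here, and "the series" means these few. Any claim that something is new, unique, unknown or untested is made for them only; others in the source may bear on it.

Measured so far in a functional assay on the whole organism for inhibition, with Rattus norvegicus as the target, read by cytopathic effect and paw edema, at a dose of 100 mg/kg by the oral route; on this read-out higher numbers stand for more inhibition at the one dose given (going by the name of the read-out) and lower numbers for less inhibition:

compound 1 `O=C(Nc1nccs1)c1c(O)c2cccnc2n(-c2ccccc2)c1=O` — 2.5%
compound 2 `O=C(NCc1cccnc1)c1c(O)c2cccnc2n(-c2ccccc2)c1=O` — 14.7%

Among the compounds with values here, compound 2 stands highest of the two numbers, with compound 1 as its only neighbour, a result that is beyond the scatter. Within the data shown here, the one measured step in this assay, a number 12.2 percentage points higher from compound 1 to compound 2 (beyond the scatter), is the only change made so far on the amide-type nitrogen, and it swaps a different kind of group than the one now in question.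

Compound 3 `Cc1cnccc1NC(=O)c1c(O)c2cccnc2n(-c2ccccc2)c1=O` differs from compound 2 by 3-methylpyridin-4-yl in place of (pyridin-3-yl)methyl on an amide-type nitrogen. Among the measured compounds shown here, no measured pair compares two pyridine-bearing groups on that nitrogen, so the measured step only shows that this position can move the read-out by a modest amount. With the same atoms joined differently, the expected step is a number 2.7 percentage points lower from compound 2 to compound 3 (within the scatter), that is none beyond the scatter, and compound 3 is estimated at 12% in this assay, within a range from 2% to 25%.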

Compound 3, a percentage reported as inhibition, in the whole organism at one dose (the size of the read-out at that dose, not a potency): 8.8%
Beside the measured number, compound 3's estimate is 3.2 percentage points above it; low and high end bracket the measured number.
By their numbers in this assay, from the lowest: compounds 1, 3 and 2 (each within the scatter of the next, the first and the last beyond it).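

In this assay, 3-methylpyridin-4-yl in place of (pyridin-3-yl)methyl on the amide-type nitrogen gives a number 5.9 percentage points lower from compound 2 to compound 3 (within the scatter), so these two groups, made of the same atoms joined differently, are not told apart on this read-out. Against the 1,3-thiazol-2-yl group the same entering group gives a number 6.3 percentage points higher from compound 1 to compound 3 (within the scatter), so compound 3 separates from neither neighbour, and only the step of a number 12.2 percentage points higher from compound 1 to compound 2 (beyond the scatter) remains beyond the scatter at this position. No supporting data bear on these differences.

Going by these compounds, whether the methyl on the pyridine ring matters by itself stays open, as a plain pyridin-4-yl group would be needed to read it. Also open, on these data alone, is how this nitrogen responds to a group of another kind, such as a longer chain ending in an amine or a carboxylic acid.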